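From dimethylamino to (tert-butoxycarbonyl)amino on compound 3

The compounds below may be only part of what the source reports. "The series", "measured", "known", "first", "only" and "open" are said of these compounds alone.

Measured in an ADME assay on BJ cells (Homo sapiens) for cytotoxicity, with a stated time of 72 h (a higher number here means that more compound is needed for the effect, a lower number that less compound is needed), so far
compound 1 `Nc1nc(-c2ccc(Cl)cc2)nn1-c1ncnc2cc(Cl)ccc12` gives > 47000 nM as a limit
compound 2 `COc1cc2ncnc(-n3nc(-c4ccccn4)nc3N)c2cc1[N+](=O)[O-]` gives > 13000 nM as a limit
compound 3 `COc1cc2ncnc(-n3nc(-c4ccccn4)nc3N)c2cc1OCCCN(C)C` gives > 25000 nM as a limit

In this assay compound 3 has only a limit, and the other two values shown are limits as well. Compound 4 `COc1cc2ncnc(-n3nc(-c4ccccn4)nc3N)c2cc1OCCCNC(=O)OC(C)(C)C` carries one change against compound 3, namely (tert-butoxycarbonyl)amino in place of dimethylamino on a saturated chain carbon, three bonds along the chain from an oxygen on an aromatic ring with the shared core left as it is. Among the measured compounds shown here, the one measured step that bears on this is a step that the two limits leave unreadable from compound 2 to compound 3 and it has no readable size. For the measured compounds named here, that step concerns the same chain, but no measured step replaces the dimethylamino group itself. The expectation therefore rests on the limit of compound 3 at > 25000 nM and gives no direction in this assay for the change. No step beyond the scatter is expected, and the estimated step reads a number no higher from compound 3 to compound 4 (the limit leaves the size open) with either direction open. Another limit is the likely outcome. For compound 4 the estimate is 25000 nM with an expected range from 8000 nM as the lower end to 60000 nM as the upper end.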

Compound 4, half-maximal effective concentration: > 12000 nM
Compound 4 gave a limit, no number; the forecaster's own chance of this, stated with the estimate: 70%; the middle value lies beyond the limit too.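

In this assay compound 4 gives > 12000 nM, which is a limit. Compound 2, compound 3 and compound 4 all stand as limits, so the steps among them cannot be read. The compounds shown leave open where any of these values truly lies, and whether (tert-butoxycarbonyl)amino in place of dimethylamino shifts the half-maximal effective concentration in either direction.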